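Inverting the Ring Stereocentre of Compound 1

The source may hold more compounds than are shown below. What is called first, only, known or untested is meant among the compounds shown, and "the series" means these compounds.

Compound 1 `CCC[C@@H](OC(C)=O)C1=C(Br)[C@@](C)(OC)OC1=O` is the reference point. In a functional assay on KB cells (Homo sapiens) for cytotoxicity (on this read-out lower numbers stand for an effect already at smaller amounts and higher numbers for an effect only at larger amounts of compound), compound 1 gives 5.4 ug/mL, the highest of the two numbers shown. Within the data shown here, compound 2 `CCC[C@@H](OC(C)=O)C1=C(Br)[C@@](CI)(OC)OC1=O` gives 2.4 ug/mL in this assay, and the step of a 2.3-fold lower number from compound 1 to compound 2 (0.35 log units; beyond the scatter) is the only measured step in this set. Compound 3 `CCCCC1=C(Br)/C(=C/Br)OC1=O` gives > 20 ug/mL in this assay, which is a limit rather than a number. Compound 4 `CCC[C@@H](OC(C)=O)C1=C(Br)[C@](C)(OC)OC1=O` is not yet measured; it differs from compound 1 as follows: the two compounds have the same atoms and bonds and differ only in configuration as drawn: 1 of 2 stereo elements differ; a stereocentre at a saturated ring carbon is drawn S in compound 1 and R in compound 4. Among the measured compounds shown here, no measured step concerns a change of configuration, so the iodo step offers no guide to direction or size here. Compound 4 is expected to give about 6 ug/mL in this assay, between 2.5 ug/mL and 15 ug/mL, which means an estimated step of a 1.1-fold higher number from compound 1 to compound 4 (0.05 log units; within the scatter).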

Compound 4, concentration for half-maximal effect: 3.9 ug/mL
For compound 4 the middle estimate is 1.5-fold (0.19 log units) above the measured one, within the range that was stated.
By their numbers in this assay, from the lowest: compounds 2, 4 and 1 (each within the scatter of the next, the first and the last beyond it). At a limit, above all of these: compound 3.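

Compounds 1 and 4 give the first read on configuration in this set, as the comparison isolates this one stereocentre at a saturated ring carbon: the fact that compounds 1 and 4 differ only in the configuration as drawn. In this assay, inverting it from S to R gives a 1.4-fold lower number from compound 1 to compound 4 (0.14 log units; within the scatter), so the two drawn configurations cannot be told apart on this read-out. Unlike the iodo replacement, this change leaves no difference beyond the usual scatter.

From the compounds shown here alone, it remains open whether the iodo group would behave alike on the R configuration and whether the second stereo element matters. Going by these compounds, how an amine or a longer chain on the shared core would read also remains unknown.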